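Compound 3 and a swap of its side group

The source may hold more compounds than are shown below. What is called first, only, known or untested is meant among the compounds shown, and "the series" means these compounds.

Compound 1 `Nc1nc(N2CCN(c3ccc(F)cc3)CC2)c2ncn([C@@H]3O[C@H](CO)[C@@H](O)[C@H]3O)c2n1`: "not active" (no number reported)
Compound 2 `CSc1ccc(Nc2ncnc3c2ncn3[C@@H]2O[C@H](CO)[C@@H](O)[C@H]2O)cc1`: "not active" (no number reported)
Compound 3 `CC(C)c1ccc(Nc2ncnc3c2ncn3[C@@H]2O[C@H](CO)[C@@H](O)[C@H]2O)cc1`: 50000 nM

For the measured compounds named here, in a functional assay on MCF7 cells (Homo sapiens) for antiproliferative activity, read by sulforhodamine B assay, with a stated time of 72 h (on this read-out higher numbers stand for weaker inhibition and lower numbers for stronger inhibition), compound 3 stands alone with 50000 nM, the only number available, while the other two compounds gave none. Compound 4 `OC[C@H]1O[C@@H](n2cnc3c(NCCC4=CCCCC4)ncnc32)[C@H](O)[C@@H]1O` differs from compound 3 in one place, on a nitrogen on an aromatic ring: 2-(cyclohex-1-en-1-yl)ethyl in place of 4-isopropylphenyl on a nitrogen on an aromatic ring. Going by the values given here, no measured pair shows what such a swap does, so the expectation is loose. Given that compound 3 reaches only 50000 nM, a small move towards stronger inhibition is expected, estimated as a 2.5-fold lower number from compound 3 to compound 4 (0.40 log units; beyond the scatter). For compound 4 the estimated value is 20000 nM, with an expected range of 3000 nM to 100000 nM. A result without any number would be no surprise.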

Compound 4, half-maximal inhibitory concentration: 3000 nM
Compound 4: the middle estimate sits 6.7-fold (0.82 log units) above what was measured; the range from low to high includes it.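

On a nitrogen on an aromatic ring, 2-(cyclohex-1-en-1-yl)ethyl in place of 4-isopropylphenyl gives a 17-fold lower number from compound 3 to compound 4 (1.22 log units; beyond the scatter) in this assay and shows that this position responds strongly to its side group, something a single number could not show. The aromatic ring leaves and a non-aromatic ring with a double bond enters, yet no measurement here explains the gain. As far as these compounds go, the swap changes the ring and its link to the nitrogen together, so which of them matters stays open. Also open, from the compounds shown here alone, is whether a 2-cyclohexylethyl group without the double bond, or a chain ending in an amine, would act alike.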